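Aryl-to-benzyl change on the cyclohexyl ether oxygen

A few compounds are considered here, and "the series" means these few. Any claim that something is new, unique, unknown or untested is made for them only; others in the source may bear on it.

Measured compounds:
compound 1 `O=C(Nc1cccc(C(F)(F)F)c1)N[C@H]1CC[C@H](Oc2ccc(C(F)(F)F)cc2)CC1`, 460 nM
compound 2 `O=C(Nc1cccc(C(F)(F)F)c1)N[C@H]1CC[C@H](Oc2cccc(F)c2)CC1`, 2400 nM

In a functional assay on CRL2813 cells (Homo sapiens) for cytotoxicity, read by sulforhodamine B assay, with a stated time of 5 days (a lower number here means a stronger inhibitor, a higher number a weaker inhibitor), compound 2 holds the higher of the two numbers, above compound 1 by a 5.2-fold higher number from compound 1 to compound 2 (0.72 log units; beyond the scatter). Compound 3 `O=C(Nc1cccc(C(F)(F)F)c1)N[C@H]1CC[C@H](OCc2ccc(F)cc2)CC1` differs from compound 2 in one place: 4-fluorobenzyl in place of 3-fluorophenyl on an oxygen on a saturated carbon. Among the measured compounds shown here, the only measured step concerns the group on that same oxygen and was modest; no measured step covers an aryl-to-benzyl change, so the direction is open. For compound 3 the number is expected to stay near that of compound 2, the estimated step being a 1.0-fold higher number from compound 2 to compound 3 (0.02 log units; within the scatter). Compound 3 is estimated at 2500 nM, within 800 nM to 8000 nM.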

Compound 3, half-maximal inhibitory concentration: 2650 nM
Compound 3: middle estimate off by 1.1-fold (0.03 log units), on the low side; measured number inside the range.
By their numbers in this assay, from the lowest: compound 1; then compounds 2 and 3 (each within the scatter of the next).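

In this assay the oxygen on a saturated carbon takes 4-fluorobenzyl in place of 3-fluorophenyl with a 1.1-fold higher number from compound 2 to compound 3 (0.04 log units; within the scatter), so in this pair the aryl-to-benzyl change brings no separation. Compound 1 still stands apart, with a 5.8-fold higher number from compound 1 to compound 3 (0.76 log units; beyond the scatter), so 4-(trifluoromethyl)phenyl remains the best group on this oxygen among the three. No data on any property of these compounds bear on this result.

Open, on these data alone, is whether 4-(trifluoromethyl)benzyl on this oxygen would match compound 1. Also open, as far as these compounds go, is how an amine or a carboxylic acid on the aromatic ring would read here.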